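Replacing the amine-bearing amide chain of compound 3

The source may report more compounds than this note shows. Statements on the series, on what has been measured and on what is new or still open speak of the compounds shown alone.

Compound 1 `CCN(CC)CCNC(=O)c1ccc(C(CC)(CC)c2ccc(OCC(=O)C(C)(C)C)c(C)c2)n1CC` gives 1600 nM
Compound 2 `CCn1c(C(=O)NCCN(C)C)ccc1C(CC)(CC)c1ccc(OCC(=O)C(C)(C)C)c(C)c1` gives 1600 nM
Compound 3 `CCn1c(C(=O)NCCN(C)C)ccc1C(CC)(CC)c1ccc(OCC(O)C(C)(C)C)c(C)c1` gives 1300 nM

All three were tested in a functional assay on Caco-2 cells (Homo sapiens), read by MTT assay, with a stated time of 48 h (on this read-out lower numbers stand for stronger inhibition and higher numbers for weaker inhibition), and compound 3, at 1300 nM in that test, sits within the scatter of both others. Compound 4 `C=CCN(C)C(=O)c1ccc(C(CC)(CC)c2ccc(OCC(O)C(C)(C)C)c(C)c2)n1CC` carries one change, allyl(methyl)amino in place of (2-(dimethylamino)ethyl)amino on a carbonyl carbon. The closest measured step, showing no change at the digits printed from compound 1 to compound 2 (within the scatter) for dimethylamino in place of diethylamino, only alters the end of this same chain. The other, showing a 1.2-fold lower number from compound 2 to compound 3 (0.09 log units; within the scatter) for 1-hydroxy-2,2-dimethylpropyl in place of (tert-butyl)carbonyl, concerns a different part of the molecule. Going by the values given here, neither step removes the whole chain, so the flat numbers so far do not test this change. A modest move toward a higher number, meaning weaker inhibition, is therefore expected only tentatively. The estimated size is a 2.3-fold higher number from compound 3 to compound 4 (0.36 log units; beyond the scatter) and it remains uncertain. Compound 4 is estimated at 3000 nM in this assay with an expected range from 900 nM to 10000 nM and a measurement still to come.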

Compound 4, half-maximal inhibitory concentration: > 50000 nM
Compound 4: a limit, no number; the forecaster's own chance of this, stated with the estimate: 15%; middle value at least 16-fold (1.22 log units) from the limit.
By their numbers in this assay, from the lowest: compounds 3, 1 and 2 (each within the scatter of the next). At a limit, above all of these: compound 4.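

Dimethylamino in place of diethylamino showed no change at the digits printed from compound 1 to compound 2 (within the scatter), so the earlier compounds only varied the chain and left its amine in place. Allyl(methyl)amino in place of (2-(dimethylamino)ethyl)amino on the carbonyl carbon, however, gives an at least 38-fold higher number from compound 3 to compound 4 (1.58 log units; beyond the scatter) in this assay, which shows that this position is far from indifferent to replacing the whole group. Compound 4 sits at a limit of the assay and has no exact number: the limit of > 50000 nM in this assay, at which 1 of the 4 values shown sits.

The compounds shown do not separate the parts of this change, since the dimethylamino group, the amide hydrogen and the two-carbon chain all leave together while allyl and methyl enter. Allylamino or (2-(dimethylamino)ethyl)(methyl)amino on the same carbonyl carbon would pull these apart, and a longer chain ending in an amine would test the chain length.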